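The compounds below may be only part of what the source reports. "The series", "measured", "known", "first", "only" and "open" are said of these compounds alone.

In a functional assay on CWR22R cells (Homo sapiens) for antiproliferative activity, read by propidium iodide staining, with a stated time of 96 h (on this read-out lower numbers stand for stronger inhibition and higher numbers for weaker inhibition), compound 1 (`CC(O)(COc1ccc(S(F)(F)(F)(F)F)cc1)C(=O)Nc1cc(C(F)(F)F)cc(C(F)(F)F)c1`) gives 3200 nM, compound 2 (`CC(O)(CS(=O)(=O)c1cccc(S(F)(F)(F)(F)F)c1)C(=O)Nc1ccc(S(F)(F)(F)(F)F)cc1`) gives 39900 nM and compound 3 (`CC(O)(CS(=O)(=O)c1cccc(C(F)(F)F)c1)C(=O)Nc1ccc(S(F)(F)(F)(F)F)cc1`) gives 23800 nM. Compound 3 therefore lies within the scatter of compound 2, and its number is clearly higher than that of compound 1, which means weaker inhibition. Compound 4 (`CC(O)(CS(=O)(=O)c1ccccc1OC(F)(F)F)C(=O)Nc1ccc(S(F)(F)(F)(F)F)cc1`) carries 2-(trifluoromethoxy)phenyl in place of 3-(trifluoromethyl)phenyl on a sulfonyl sulfur. Among the measured compounds shown here, only one measured step touches this part of the molecule, a 1.7-fold lower number from compound 2 to compound 3 (0.22 log units; within the scatter), and it stayed small. It involved a different exchange, so it is only a loose guide, and no change beyond the scatter is expected. The expected step is a 1.1-fold lower number from compound 3 to compound 4 (0.03 log units; within the scatter). Compound 4 is estimated at 22000 nM, with an expected range from 8000 nM to 55000 nM.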

Compound 4, half-maximal inhibitory concentration: 16000 nM
For compound 4 the middle estimate is 1.4-fold (0.14 log units) above the measured one, and the stated range covers the measured number.
By their numbers in this assay, from the lowest: compound 1; then compounds 4, 3 and 2 (each within the scatter of the next, the first and the last beyond it).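

In this assay, replacing 3-(trifluoromethyl)phenyl with 2-(trifluoromethoxy)phenyl on the sulfonyl sulfur gives a 1.5-fold lower number from compound 3 to compound 4 (0.17 log units; within the scatter). This exchange adds an oxygen and a hydrogen-bond acceptor, yet the numbers stay within the scatter, as they did for the earlier exchange on this aromatic ring. No separate measurement bears on this result. The exchange alters both the group and its place on the ring, so the compounds shown cannot separate the two. Also open, going by these compounds, is how an amine or a carboxylic acid on this ring would read out.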